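Methyl on the pyridin-3-yl carbonyl: cytotoxicity notes

A few compounds are considered here, and "the series" means these few. Any claim that something is new, unique, unknown or untested is made for them only; others in the source may bear on it.

Measured compounds:
compound 1 `Cn1cc(C2CC(c3ccccc3)=NN2C(=O)c2cccnc2)c2ccccc21`: > 300000 nM
compound 2 `Cc1ccc(C(=O)N2N=C(c3ccccc3)CC2c2cn(C)c3ccccc23)cn1`: 154000 nM
compound 3 `COc1cccc(C2=NN(C(=O)c3cccnc3)C(c3cn(C)c4ccc(OC)cc34)C2)c1`: 125000 nM

In an ADME assay on HEK-293T cells (Homo sapiens) for cytotoxicity, read by MTT assay, with a stated time of 48 h (a lower number here means that less compound is tolerated, a higher number that more compound is tolerated), compound 1 gives only a limit of the assay, > 300000 nM, not a number; this is the limit of > 300000 nM in this assay, at which 1 of the 3 values shown sits. Compound 2 carries methyl in place of hydrogen on an aromatic carbon on the core of compound 1, and this assay shows an at least 1.9-fold lower number from compound 1 to compound 2 (0.28 log units; that floor lies within the scatter). Compound 3 has a different core from compound 1; the difference between the two cores is not broken down here. In this assay compound 3 gives 125000 nM. Compound 4 `COc1cccc(C2=NN(C(=O)c3ccc(C)nc3)C(c3cn(C)c4ccc(OC)cc34)C2)c1` carries the same change on compound 3, namely (methyl in place of hydrogen on an aromatic carbon), at a place described in the same words as before.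

Compound 4 is expected to show a 1.3-fold lower number from compound 3 to compound 4 (0.12 log units; within the scatter). Among the measured compounds shown here, this expectation rests on the measured pair because an at least 1.9-fold lower number from compound 1 to compound 2 (0.28 log units; that floor lies within the scatter) is the only earlier instance of this change and lies at the floor of the scatter. Compound 4 is therefore estimated at 95000 nM in this assay.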

Compound 4, half-maximal cytotoxic concentration: > 300000 nM
Compound 4 gave a limit, no number; the forecaster's own chance of this, stated with the estimate: 10%; middle value at least 3.1-fold (0.49 log units) from the limit.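

In this assay compound 4 gives only a limit of the assay, > 300000 nM, not a number. Going from pyridin-3-yl to 6-methylpyridin-3-yl gives an at least 2.4-fold higher number from compound 3 to compound 4 (0.38 log units; beyond the scatter), so the step seen on the core of compound 1 does not carry over to the core of compound 3 in direction: the same change on two cores in this assay, an at least 1.9-fold lower number (0.28 log units; that floor lies within the scatter) from compound 1 to compound 2 and an at least 2.4-fold higher number (0.38 log units; beyond the scatter) from compound 3 to compound 4, at least 4.6-fold (0.66 log units) apart, beyond the scatter of two such steps. This rests on two pairs, each with a limit at one end, so it does not show the true size of either step: the limit of > 300000 nM in this assay, at which 2 of the 4 values shown sit.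

Open, going by these compounds, is which difference between the two cores goes with the change of direction. Also open, on these data alone, is whether ethyl, an amine or a carboxylic acid on the same aromatic carbon would follow methyl on either core.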